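The source may hold more compounds than are shown below. What is called first, only, known or untested is meant among the compounds shown, and "the series" means these compounds.

In a functional assay on OVCAR-3 cells (Homo sapiens) for cytotoxicity, read by sulforhodamine B assay, with a stated time of 48 h (on this read-out lower numbers stand for stronger inhibition of growth and higher numbers for weaker inhibition of growth), compound 1 (`COc1cc(C(=O)c2ccc3c(c2)oc(=O)n3S(C)(=O)=O)cc(OC)c1OC`) gives 1560 nM, compound 2 (`COc1ccc(C(=O)c2cc(OC)c(OC)c(OC)c2)c(OC)c1O`) gives 22.2 nM, and compound 3 (`COc1ccc(C(=O)c2cc(OC)c(OC)c(OC)c2)c(OC)c1N`) gives 20.2 nM. Compound 3 thus shares the low end of the range with compound 2, and both lie far under compound 1. Compound 4 (`COc1ccc(C(=O)c2cc(OC)c(OC)c(OC)c2)c(OC)c1NC(C)=O`) has not yet been measured. It differs from compound 3 by acetyl in place of hydrogen on a nitrogen on an aromatic ring, amino to acetamido: acetyl in place of hydrogen on a nitrogen on an aromatic ring. Among the compounds with values here, only one measured step touches this place: a 1.1-fold lower number from compound 2 to compound 3 (0.04 log units; within the scatter), with amino in place of hydroxy on an aromatic carbon. Within the data shown here, that step does not test acetyl on the nitrogen, and no measured pair does. Compound 3 at 20.2 nM already sits at the low end of the numbers seen, so a change of this size is expected to move upward, though not as far as the number of compound 1. The expected step in this assay is a 5.9-fold higher number from compound 3 to compound 4 (0.77 log units; beyond the scatter). For compound 4 the estimated value is 120 nM, with an expected range from 25 nM to 600 nM.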

Compound 4, concentration for 50% growth inhibition: 3300 nM
Compound 4: middle estimate off by 28-fold (1.44 log units), on the low side, outside the stated range (above it).
By their numbers in this assay, from the lowest: compounds 3 and 2 (each within the scatter of the next); then compound 1; then compound 4.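

In this assay, acetyl in place of hydrogen on the nitrogen gives a 160-fold higher number from compound 3 to compound 4 (2.21 log units; beyond the scatter), so this place, where amino and hydroxy had read alike in a 1.1-fold lower number from compound 2 to compound 3 (0.04 log units; within the scatter), does not accept every group. Measured against the hydroxy compound, acetamido gives a 150-fold higher number from compound 2 to compound 4 (2.17 log units; beyond the scatter), which shows that the earlier match between two groups says little about a larger change at the same carbon. No measurement shown here accounts for this large step.

The compounds shown leave open whether the step belongs to the acetyl group in particular or would follow from any group on this nitrogen, such as a plain methyl or a longer acyl chain. They also leave open how a dimethylamino group or a carboxylic acid would read at this place.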